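The source may report more compounds than this note shows. Statements on the series, on what has been measured and on what is new or still open speak of the compounds shown alone.

Compound 1 `CCCCCSc1nc(C(F)(F)F)ccc1CNC(=O)C(C)c1ccc(NS(C)(=O)=O)c(F)c1`: 2.5 nM
Compound 2 `CC(C(=O)NCc1ccc(C(F)(F)F)nc1SCCC(=O)O)c1ccc(NS(C)(=O)=O)c(F)c1`: "not active" (no number reported)
Compound 3 `COC(=O)CCSc1nc(C(F)(F)F)ccc1CNC(=O)C(C)c1ccc(NS(C)(=O)=O)c(F)c1`: 48.2 nM

In an assay on CHO-K1 cells for antagonist activity at transient receptor potential cation channel subfamily V member 1 (Homo sapiens), read by FLIPR (on this read-out lower numbers stand for stronger inhibition and higher numbers for weaker inhibition), compound 3 gives 48.2 nM, the higher of the two numbers reported. Compound 2 gave no number at all. Compound 1 gives 2.5 nM. Compound 4 `CC(C(=O)NCc1ccc(C(F)(F)F)nc1[S+]([O-])C1CCCCC1)c1ccc(NS(C)(=O)=O)c(F)c1` differs from compound 3 in one place: a group of 8 heavy atoms (6 carbon, 1 oxygen, 1 sulfur; one six-membered non-aromatic ring of carbon only) in place of a group of 7 heavy atoms (4 carbon, 2 oxygen, 1 sulfur; no ring), on an aromatic carbon. Going by the values given here, the only measured step at this position, a 19-fold higher number from compound 1 to compound 3 (1.29 log units; beyond the scatter), shows that exchanging the group on this aromatic carbon can move the number a great deal. Like compound 1, compound 4 lacks the methoxycarbonyl that compound 3 carries, so a step downward in this assay is expected for compound 4, about a 4.0-fold lower number from compound 3 to compound 4 (0.60 log units; beyond the scatter). The estimate for compound 4 is 12 nM, with a likely range from 3 nM to 50 nM.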

Compound 4, inhibition constant: "not active" (no number reported)
No number was reported for compound 4; no gap can be computed for the estimate.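

Going by these compounds alone, compound 4 gave no number, so no step from compound 3 to compound 4 can be read, and no measured evidence here bears on this result. The compounds shown leave open which feature of the group on this aromatic carbon goes with a "not active" result.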